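Flipping the enone: a rearranged chalcone on a shared core

This account rests on a few compounds, and the source may have more. Where it says the series, first, only, none or still open, it means among the compounds named here.

Measured compounds:
- compound 1, `COc1ccc(-c2cc(/C=C/C(=O)c3cc(OC)c(OC)c(OC)c3)nc3cc(-c4ccccc4)nn23)cc1OC`: 35000 nM
- compound 2, `COc1ccc(-c2cc(/C=C/C(=O)c3ccc(Cl)cc3)nc3cc(-c4ccccc4)nn23)cc1OC`: 44100 nM
- compound 3, `COc1ccc(/C=C/C(=O)c2cc(-c3cc(OC)c(OC)c(OC)c3)n3nc(-c4ccccc4)cc3n2)cc1OC`: 41000 nM

Of the compounds shown here, three built on the same fused core have been tested in an ADME assay on HEK293 cells (Homo sapiens) for antiproliferative activity, read by MTT assay, with a stated time of 24 h; a lower number here means a stronger inhibitor, a higher number a weaker inhibitor. Compound 1 gives 35000 nM, compound 2 gives 44100 nM and compound 3 gives 41000 nM. Among the measured compounds shown here, the three numbers lie close together; the only step computed between them, a 1.3-fold higher number from compound 1 to compound 2 (0.10 log units; within the scatter), shows that swapping the aryl group on the carbonyl carbon left the read-out essentially unchanged, and the gap from compound 2 to compound 3 is smaller still.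

Compound 4, `COc1ccc(-c2cc(C(=O)/C=C/c3ccc(Cl)cc3)nc3cc(-c4ccccc4)nn23)cc1OC`, keeps every atom of compound 2 but joins them differently: (2-(4-chlorophenyl)ethenyl)carbonyl in place of 2-((4-chlorophenyl)carbonyl)ethenyl on an aromatic carbon. The carbonyl and the double bond of the chain trade places, so the carbonyl now sits directly on the core and the 4-chlorophenyl group on the far end of the chain.

For the measured compounds named here, no measured step reverses a chain in this way, so nothing in the data speaks for or against a change. Given that the one related step, a 1.3-fold higher number from compound 1 to compound 2 (0.10 log units; within the scatter), was flat, the expectation for a 1.0-fold lower number from compound 2 to compound 4 (0.00 log units; within the scatter) is a step no larger than the scatter, in no particular direction. Compound 4 is therefore expected to give about 44000 nM, within 22000 nM to 88000 nM.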

Compound 4, half-maximal inhibitory concentration: 39100 nM
The estimate for compound 4 lay 1.1-fold (0.05 log units) above the measured number; the measured number falls inside the stated range.
By their numbers in this assay, from the lowest: compounds 1, 4, 3 and 2 (each within the scatter of the next).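

Reversing the chain on this aromatic carbon, so that the carbonyl sits directly on the core and the double bond leads out to the 4-chlorophenyl group, gives a 1.1-fold lower number from compound 2 to compound 4 (0.05 log units; within the scatter) in this assay. The earlier step changed only the aryl group on the carbonyl carbon, whereas this pair tests the order of the chain itself, and with the same atoms joined differently, the change stays within the scatter. For this one pair, then, the direction of the chain makes no readable difference in this assay, and no other measurement here bears on this result or offers an explanation for it.

A single pair cannot show whether reversing the chain would read the same with a different group at its far end, such as 3,4,5-trimethoxyphenyl. The compounds shown also leave open whether anything at this position could move the number beyond the scatter, for example a chain ending in an amine or a carboxylic acid, or a longer chain with a second double bond.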